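Hydroxymethyl in place of cyano: compound 3 to compound 4

The source may report more compounds than this note shows. Statements on the series, on what has been measured and on what is new or still open speak of the compounds shown alone.

The shared core is that of compound 1 `Cc1cc(NNC(=O)Nc2cc(Cl)nc(Cl)c2)ncc1N(C)C`, which in a functional assay on CHO cells for antagonist activity at sphingosine 1-phosphate receptor 2 (Homo sapiens), read by fluorescence and calcium flux, with a stated time of 3 min (on this read-out lower numbers stand for stronger inhibition and higher numbers for weaker inhibition), gives 3600 nM. Going by the values given here, compound 2 `Cc1cc(NNC(=O)Nc2cc(Cl)nc(Cl)c2)ncc1C#N` carries cyano in place of dimethylamino on an aromatic carbon and in this assay gives 6000 nM; the step of a 1.7-fold higher number from compound 1 to compound 2 (0.22 log units; within the scatter) is the only single-point comparison measured so far. Compound 3 `Cc1cc(C#N)nc(NNC(=O)Nc2cc(Cl)nc(Cl)c2)c1` is the third member of the series. In this assay compound 3 gives only a limit, > 6600 nM, and so stands at the edge of the measurable range, where (the limit of > 6600 nM in this assay, at which 1 of the 3 values shown sits).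

Compound 4 `Cc1cc(CO)nc(NNC(=O)Nc2cc(Cl)nc(Cl)c2)c1` differs from compound 3 by hydroxymethyl in place of cyano on an aromatic carbon. No measured step exchanges cyano for hydroxymethyl, and the one step involving cyano, a 1.7-fold higher number from compound 1 to compound 2 (0.22 log units; within the scatter), stays within the scatter; the numbers shown therefore give no basis for expecting a step beyond the scatter in this assay in either direction, and the starting point is itself a limit rather than a number. Compound 4 is accordingly expected to read close to 8000 nM, with a range from 2500 nM to 25000 nM, and with a real chance that this assay again reports only a limit. The step that the limit leaves unreadable from compound 3 to compound 4 is the estimated change, not a measured one.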

Compound 4, half-maximal inhibitory concentration: > 6600 nM
Compound 4 ended at the assay's limit; the forecaster's own chance of this, stated with the estimate: 55%; the middle value is on the limit's open side.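

No step from compound 3 to compound 4 can be read in this assay, because both compounds give only a limit and not a number: the limit of > 6600 nM in this assay, at which 2 of the 4 values shown sit.

The compounds shown leave open how far cyano and hydroxymethyl on this aromatic carbon differ in this assay and whether either group can give a reading inside the measurable range.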